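Second chloro on the aryl group of compound 2

This account rests on a few compounds, and the source may have more. Where it says the series, first, only, none or still open, it means among the compounds named here.

The series shares one core and differs only in the aryl group on an aromatic nitrogen. Compound 1 `COc1cc2c(Oc3ccc(NC(=O)c4nn(-c5ccccc5OC(F)(F)F)c(=O)cc4C)cc3F)ccnc2cc1OCCCN1CCCCC1` carries 2-(trifluoromethoxy)phenyl there; in a functional assay on HT-29 cells (Homo sapiens) for inhibition, read by MTT assay, with a stated time of 72 h (a higher number here means a weaker inhibitor, a lower number a stronger inhibitor), compound 1 gives 190 nM. Compound 2 `COc1cc2c(Oc3ccc(NC(=O)c4nn(-c5ccc(Cl)cc5)c(=O)cc4C)cc3F)ccnc2cc1OCCCN1CCCCC1` carries 4-chlorophenyl; in this assay compound 2 gives 360 nM. Among the measured compounds shown here, of the two numbers measured so far, compound 2 holds the numerically higher one, but the step of a 1.9-fold higher number from compound 1 to compound 2 (0.28 log units; within the scatter) is within the scatter, so the two compounds are not distinguished by this assay.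

Compound 3 `COc1cc2c(Oc3ccc(NC(=O)c4nn(-c5ccc(Cl)cc5Cl)c(=O)cc4C)cc3F)ccnc2cc1OCCCN1CCCCC1` is not yet measured. It differs from compound 2 by chloro in place of hydrogen on an aromatic carbon. For the measured compounds named here, only one measured step exists, a 1.9-fold higher number from compound 1 to compound 2 (0.28 log units; within the scatter), and it exchanges the whole aryl group rather than adding one chloro to it; it was within the scatter. Nothing measured speaks directly to a second chloro on this ring. The expected step for compound 3 is therefore a 1.2-fold lower number from compound 2 to compound 3 (0.08 log units; within the scatter) in this assay, nothing beyond the scatter, with a wide range. The estimate for compound 3 in this assay is 300 nM, between 110 nM and 850 nM.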

Compound 3, half-maximal inhibitory concentration: 290 nM
Beside the measured number, compound 3's estimate is 1.0-fold (0.01 log units) above it, and the stated range covers the measured number.
By their numbers in this assay, from the lowest: compounds 1, 3 and 2 (each within the scatter of the next).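

In this assay, among the compounds shown here, the change from 4-chlorophenyl to 2,4-dichlorophenyl is the first step that alters this aryl group by a single atom, and it gives a 1.2-fold lower number from compound 2 to compound 3 (0.09 log units; within the scatter). A chloro in place of hydrogen on this aromatic carbon, ortho to a large group and meta to a chloro group, therefore leaves the number within the scatter, which the whole-group exchange measured earlier could not show. Exchanging the whole aryl group again gives a 1.5-fold higher number from compound 1 to compound 3 (0.18 log units; within the scatter), so 2-(trifluoromethoxy)phenyl, 4-chlorophenyl and 2,4-dichlorophenyl are not distinguished in this read-out, and nothing available explains these small steps.

On these data alone, whether an amine, a carboxylic acid or a methoxy group on this same aromatic carbon would move the number beyond the scatter remains open. Also open, as far as these compounds go, is whether this chloro would behave the same way on a phenyl group without the 4-chloro, since its only measured setting is the 4-chlorophenyl group of the series.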